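The source may report more compounds than this note shows. Statements on the series, on what has been measured and on what is new or still open speak of the compounds shown alone.

Measured compounds:
Compound 1, `CS(=O)(=O)c1cccc(S(=O)(=O)c2ccc3c(c2)CCC[C@H]3CN)c1`: 3.98 nM
Compound 2, `O=C(NC[C@@H]1CCCc2cc(S(=O)(=O)c3cccc(F)c3)ccc21)[C@H]1CCCN1`: 0.631 nM
Compound 3, `O=C1CN(C[C@@H]2CCCc3cc(S(=O)(=O)c4cccc(F)c4)ccc32)CCN1`: 6.31 nM

In an assay on isolated protein for displacement of a labelled ligand from 5-hydroxytryptamine receptor 6 (Homo sapiens) (a higher number here means a weaker inhibitor, a lower number a stronger inhibitor), compound 3 gives 6.31 nM, the highest of the three numbers. Compound 1 gives 3.98 nM, which lies within the scatter of compound 3, while compound 2 gives 0.631 nM, the lowest number of the set. Compound 4, `CNC(=O)NC[C@@H]1CCCc2cc(S(=O)(=O)c3cccc(F)c3)ccc21`, has not yet been measured; it differs from compound 3 in one place: (methylcarbamoyl)amino in place of 3-oxopiperazin-1-yl on a saturated chain carbon bound to a saturated ring carbon.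

Going by the values given here, the one step that bears on this change is a 10-fold higher number from compound 2 to compound 3 (1.00 log units; beyond the scatter). There, an amide-bearing chain gave way to the 3-oxopiperazin-1-yl group, and the number rose. In compound 4 the ring leaves again and a (methylcarbamoyl)amino group, which like the group in compound 2 carries a carbonyl attached to a nitrogen, enters on the same chain carbon. Compound 4 is therefore expected to move back toward compound 2 rather than to stay near compound 3, though the urea and the amide are not identical and the full return is not assured. The estimate for compound 4 is a 3.9-fold lower number from compound 3 to compound 4 (0.60 log units; beyond the scatter). The expected value for compound 4 in this assay is 1.6 nM, with a range from 0.5 nM to 5 nM.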

Compound 4, inhibition constant: 0.398 nM
Beside the measured number, compound 4's estimate is 4.0-fold (0.60 log units) above it, outside the stated range (below it).
By their numbers in this assay, from the lowest: compounds 4 and 2 (each within the scatter of the next); then compounds 1 and 3 (each within the scatter of the next).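

In this assay, an open (methylcarbamoyl)amino group on a saturated chain carbon bound to a saturated ring carbon gives a 16-fold lower number from compound 3 to compound 4 (1.20 log units; beyond the scatter) and so shows that a ring is not needed at this position for a low number. With methylamino in place of pyrrolidin-2-yl on a carbonyl carbon, the result is a 1.6-fold lower number from compound 2 to compound 4 (0.20 log units; within the scatter) and so the pyrrolidin-2-yl ring of compound 2 can be lost without a change beyond the scatter, leaving compound 3 alone among these three with a higher number. Nothing available explains these differences.

From the compounds shown here alone, it remains open whether an ethyl or a longer chain on the urea nitrogen, or a simple acetyl amide in its place, would keep the number this low. Compound 1 differs from the others in more than one place, so its steps cannot be read.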